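From Phenoxy to Fluorophenyl on a Shared Core

The source may hold more compounds than are shown below. What is called first, only, known or untested is meant among the compounds shown, and "the series" means these compounds.

Of the compounds shown here, three with a shared core have been measured in an ADME assay for permeability, using PAMPA, with a stated time of 30 min, at pH 7.4; on this read-out lower numbers stand for lower permeability and higher numbers for higher permeability. Compound 1 (`COc1ccc(F)cc1CNCCCNc1ccnc2cc(Cc3ccc(C#N)cc3)ccc12`), which carries 4-cyanobenzyl, gives 23 10^-6 cm/s. Compound 2 (`COc1ccc(F)cc1CNCCCNc1ccnc2cc(Oc3ccc(F)cc3)ccc12`), with 4-fluorophenoxy in that place, gives 317 10^-6 cm/s, and compound 3 (`COc1cccc(Oc2ccc3c(NCCCNCc4cc(F)ccc4OC)ccnc3c2)c1`), with 3-methoxyphenoxy, gives 317 10^-6 cm/s. Compound 3 therefore stands level with compound 2, and the two share the top number of the three.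

Compound 4 (`COc1ccc(F)cc1CNCCCNc1ccnc2cc(-c3ccc(F)cc3)ccc12`) has 4-fluorophenyl in place of 3-methoxyphenoxy on an aromatic carbon.

Going by the values given here, three measured steps bear on this change. Replacing 4-cyanobenzyl at this place gave a 14-fold higher number from compound 1 to compound 2 (1.14 log units; beyond the scatter) and a 14-fold higher number from compound 1 to compound 3 (1.14 log units; beyond the scatter), both large, so the group here can move the number a long way. Changing only the ring on the oxygen gave no change at the digits printed from compound 2 to compound 3 (within the scatter), which lies within the scatter. Among the compounds with values here, no measured step shows what losing that oxygen does, so this forecast is uncertain. Compound 4 keeps an aromatic ring of carbon only and has no nitrile, so the expected result is a small drop at most, not one beyond the scatter: a 1.3-fold lower number from compound 3 to compound 4 (0.10 log units; within the scatter). For compound 4 the estimated value is 250 10^-6 cm/s, with an expected range from 100 10^-6 cm/s to 500 10^-6 cm/s.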

Compound 4, apparent permeability: 237 10^-6 cm/s
Compound 4: the middle estimate sits 1.1-fold (0.02 log units) above what was measured; the range from low to high includes it.
By their numbers in this assay, from the lowest: compound 1; then compounds 4, 2 and 3 (each within the scatter of the next).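

Compound 4 is the first compound shown with its ring attached directly to the shared core, with no oxygen in between. Compound 2 makes the cleanest comparison, since both compounds carry a ring with fluorine at the 4-position and only the oxygen is gone: in this assay there is a 1.3-fold lower number from compound 2 to compound 4 (0.13 log units; within the scatter), and the comparison with the methoxy compound reads the same, with a 1.3-fold lower number from compound 3 to compound 4 (0.13 log units; within the scatter), so at this position the oxygen link proves unnecessary for keeping the number in the range of the two phenoxy compounds. Compound 1 now stands apart from all three others, with a 10-fold higher number from compound 1 to compound 4 (1.01 log units; beyond the scatter) added to its two earlier large steps, and this shows that the high numbers do not depend on the oxygen and that something particular to 4-cyanobenzyl goes with the low one.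

Still open, from the compounds shown here alone, is whether that low number goes with the single carbon link or with the nitrile, a question that 4-fluorobenzyl and 4-cyanophenyl at this place could separate. Nothing measured here speaks to the reason compound 1 stands apart from the others.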